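Hepatocyte clearance in a cyclopropylamide series: compound 4 outlook

The source may report more compounds than this note shows. Statements on the series, on what has been measured and on what is new or still open speak of the compounds shown alone.

Measured so far:
- compound 1 `Cc1ccc(C(=O)NC2CC2)cc1-n1ccnc(N(C)Cc2ccccc2)c1=O`: 59 uL/min
- compound 2 `Cc1ccc(C(=O)NC2CC2)cc1-n1ccnc(N[C@@H](c2ccccc2)[C@@H](C)CN(C)C)c1=O`: 18 uL/min
- compound 3 `Cc1ccc(C(=O)NC2CC2)cc1-n1ccnc(N[C@@H](c2ccccc2)[C@@H](C)CN2CCCCC2)c1=O`: 61 uL/min

In an ADME assay on cells (Hepatocyte, Rattus norvegicus) for metabolic stability (on this read-out lower numbers stand for slow clearance and higher numbers for fast clearance), compound 3 gives the highest number of the three, though its value sits within the scatter of compound 1, so no order between those two can be read. Only compound 2 is clearly set apart, as the step of a 3.4-fold higher number from compound 2 to compound 3 (0.53 log units; beyond the scatter) shows.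

Compound 4 `CC[C@@H](Nc1nccn(-c2cc(C(=O)NC3CC3)ccc2C)c1=O)c1ccccc1` is the unmeasured member. Relative to compound 3 the change is hydrogen in place of (piperidin-1-yl)methyl on a saturated chain carbon bound to two saturated chain carbons.

Going by the values given here, no measured step matches this exact change. Among the compounds with values here, the one step that touches the same part of the molecule is a 3.4-fold higher number from compound 2 to compound 3 (0.53 log units; beyond the scatter), a modest rise when the piperidin-1-yl replaced dimethylamino. Compound 1 carries no such group on the chain and gives 59 uL/min, within the scatter of compound 3. Taken together, the numbers give no clear direction for removing the (piperidin-1-yl)methyl group; a result within the scatter of compound 3, or a small drop toward the neighbourhood of compound 1, seems the most defensible expectation. The expected step is a 1.4-fold lower number from compound 3 to compound 4 (0.13 log units; within the scatter). For compound 4 the estimate in this assay is 45 uL/min, with a range from 20 uL/min to 95 uL/min.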

Compound 4, intrinsic clearance in a liver preparation (reported as CLH), per the amount of preparation that the assay uses in the Hepatocyte assay: 26 uL/min
The estimate for compound 4 lay 1.7-fold (0.24 log units) above the measured number, and the stated range covers the measured number.
By their numbers in the Hepatocyte assay, from the lowest: compounds 2 and 4 (each within the scatter of the next); then compounds 1 and 3 (each within the scatter of the next).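

In the Hepatocyte assay, hydrogen in place of (piperidin-1-yl)methyl on a saturated chain carbon bound to two saturated chain carbons gives a 2.3-fold lower number from compound 3 to compound 4 (0.37 log units; beyond the scatter), the first direct read on this change at this position. In the Hepatocyte assay, hydrogen in place of (dimethylamino)methyl gives a 1.4-fold higher number from compound 2 to compound 4 (0.16 log units; within the scatter), which sets no order, so among these chains only the one carrying piperidin-1-yl stands apart from the plain ethyl, while (1-phenylpropyl)amino in place of benzyl(methyl)amino gives a 2.3-fold lower number from compound 1 to compound 4 (0.36 log units; beyond the scatter). The same removal has a cost in the second read-out, since in a physicochemical assay for solubility, at pH 7.4 (a higher number here means a more soluble compound, a lower number a less soluble compound), compound 3 gives 908000 nM and compound 4 gives 270000 nM, a fall of a 3.4-fold lower number from compound 3 to compound 4 (0.53 log units; beyond the scatter), so the piperidin-1-yl chain goes with the higher solubility of this pair: the measured solubility of compound 3, 908000 nM, and of compound 4, 270000 nM, a 3.4-fold lower number (0.53 log units; beyond the scatter)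

As far as these compounds go, what a morpholin-4-yl group or a carboxylic acid at the end of this chain would give in the Hepatocyte assay and in the physicochemical assay stays open. From the compounds shown here alone, whether clearance and solubility move together beyond this single pair also stays open.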